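Pyridylmethylamine series: ring-to-ring-methyl swap at the amine nitrogen

A few compounds are considered here, and "the series" means these few. Any claim that something is new, unique, unknown or untested is made for them only; others in the source may bear on it.

Two compounds carry numbers in an assay on isolated protein for inhibition of protein kinase C theta type (Homo sapiens), read by TR-FRET, with a stated time of 2 h; a higher number here means a weaker inhibitor, a lower number a stronger inhibitor. Compound 1 `N#Cc1cnc(NCc2ccccc2C(F)(F)F)cc1N[C@H]1CC[C@@H](O)CC1` gives 140 nM in this assay. Compound 2 `CO[C@H]1CC[C@H](Nc2cc(NCc3cnccc3C(F)(F)F)ncc2C#N)CC1` gives 1100 nM in this assay, the higher of the two numbers, and the gap to compound 1 lies beyond the scatter of repeated measurement. Among the compounds with values here, no pair differs in a single place, so no step between measured compounds can be counted.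

Compound 3 `N#Cc1cnc(NCc2cnccc2C(F)(F)F)cc1NCC1CCOCC1` has not yet been measured in this assay. It differs from compound 2 by (oxan-4-yl)methyl in place of 4-methoxycyclohexyl on a nitrogen on an aromatic ring. The ring attached to the nitrogen is thus replaced by a ring-bearing one-carbon linker, and the two defined stereocentres of compound 2 are gone. Within the data shown here, no measured pair shows what this exchange does, so the direction is open; a step of modest size, not clearly beyond the scatter, is expected for the step of a 1.4-fold higher number from compound 2 to compound 3 (0.13 log units; within the scatter). Compound 3 is accordingly estimated at 1500 nM in this assay, within a range of 400 nM to 5000 nM.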

Compound 3, half-maximal inhibitory concentration: 400 nM
The estimate for compound 3 lay 3.8-fold (0.57 log units) above the measured number; the measured number falls inside the stated range.
By their numbers in this assay, from the lowest: compound 1; then compound 3; then compound 2.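

Within the data shown here, on the nitrogen on an aromatic ring, (oxan-4-yl)methyl in place of 4-methoxycyclohexyl gives a 2.8-fold lower number from compound 2 to compound 3 (0.44 log units; beyond the scatter) in this assay and provides the first single-place step. The two groups have the same counted hydrogen-bond donors and acceptors, whereas the entering group has a hetero atom in its six-membered ring and lacks the defined stereocentres of the leaving group. Nothing available bears on the cause of this step.

From the compounds shown here alone, it remains open whether the step follows the ring oxygen or the linker carbon; oxan-4-yl directly on the nitrogen and cyclohexylmethyl would separate these two changes. Going by these compounds, the effect of a longer chain, such as 2-(oxan-4-yl)ethyl, on the same nitrogen also remains open.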